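Adding a second methyl to the sulfonyl aryl ring

A few compounds are considered here, and "the series" means these few. Any claim that something is new, unique, unknown or untested is made for them only; others in the source may bear on it.

Measured compounds:
compound 1 `O=C(/C=C/c1cccc(NS(=O)(=O)c2ccccc2Cl)c1)c1nc2ccccc2[nH]1` gives 987 nM in a functional assay on HCT-116 cells (Homo sapiens) for antiproliferative activity, read by MTT assay, with a stated time of 48 h; a lower number here means a stronger inhibitor, a higher number a weaker inhibitor
compound 2 `Cc1cccc(S(=O)(=O)Nc2cccc(/C=C/C(=O)c3nc4ccccc4[nH]3)c2)c1` gives 597 nM in this assay

Going by the values given here, compound 2 has the lowest of the two numbers so far in this assay, but its nearest neighbour, compound 1, lies within the scatter of it: the two cannot be ranked. Among the compounds with values here, the one measured step, a 1.7-fold lower number from compound 1 to compound 2 (0.22 log units; within the scatter), swapped one sulfonyl aryl group for another and changed nothing beyond the scatter.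

Compound 3 `Cc1cc(C)cc(S(=O)(=O)Nc2cccc(/C=C/C(=O)c3nc4ccccc4[nH]3)c2)c1` differs from compound 2 by methyl in place of hydrogen on an aromatic carbon. Within the data shown here, no measured pair shows exactly this change; the only step that bears on it, a 1.7-fold lower number from compound 1 to compound 2 (0.22 log units; within the scatter), suggests that changes on this ring leave the number close to where it was. Compound 3 is therefore expected to give about 500 nM in this assay, with a range from 200 nM to 1500 nM, meaning an estimated step of a 1.2-fold lower number from compound 2 to compound 3 (0.08 log units; within the scatter) that stays within the scatter.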

Compound 3, half-maximal inhibitory concentration: 1220 nM
Beside the measured number, compound 3's estimate is 2.4-fold (0.39 log units) below it; the measured number falls inside the stated range.
By their numbers in this assay, from the lowest: compounds 2, 1 and 3 (each within the scatter of the next, the first and the last beyond it).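

In this assay, going by these compounds alone, the second methyl on the sulfonyl aryl ring is the first change here to move the number beyond the scatter, with a 2.0-fold higher number from compound 2 to compound 3 (0.31 log units; beyond the scatter) as 3-methylphenyl becomes 3,5-dimethylphenyl. The step is modest, but it shows that this ring position does respond to one added methyl, and compound 3 is the weaker of this pair. Against the chlorinated compound, a 1.2-fold higher number from compound 1 to compound 3 (0.09 log units; within the scatter) stays within the scatter, so compound 1 and compound 3 cannot be ranked, and no measurement available here explains why the added methyl raised the number.

Open, as far as these compounds go, is whether the rise belongs to methyl itself or to any group at this position. A fluorine, a methoxy group or an ethyl chain there would begin to separate those two readings.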